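One Amine Swap on a Shared Core

The source may report more compounds than this note shows. Statements on the series, on what has been measured and on what is new or still open speak of the compounds shown alone.

Of the compounds shown here, three built on one shared core have been measured so far. Compound 1 `CCOC(=O)c1cc(=O)c2cc(CSC(=S)N(C)c3ccccc3)ccc2o1` was tested in a functional assay on LM7 cells (Homo sapiens) for antiproliferative activity, read by MTT assay, with a stated time of 72 h; on this read-out lower numbers stand for stronger inhibition and higher numbers for weaker inhibition. In this assay compound 1 reached only the limit of > 25000 nM, so no number is known for it. Compound 2 `O=c1c(Cl)c(CSC(=S)N2CCOCC2)oc2ccccc12` gives 19200 nM in this assay, a number rather than a limit. Compound 3 `O=c1c(CSC(=S)N2CCN(C(c3ccc(F)cc3)c3ccc(F)cc3)CC2)coc2ccccc12` likewise reached only the limit of > 25000 nM in this assay. Where compound 1 stands is therefore summed up by the limit of > 25000 nM in this assay, at which 2 of the 3 values shown sit; it sits at the limit, and the only number among the three belongs to compound 2.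

Compound 4 `CCOC(=O)c1cc(=O)c2cc(CSC(=S)N3CCCCC3)ccc2o1` differs from compound 1 in one place: piperidin-1-yl in place of methyl(phenyl)amino on a thiocarbonyl carbon. Among the compounds with values here, no measured pair isolates this change, so its size is not known from the data. Because the limit of > 25000 nM in this assay, at which 2 of the 3 values shown sit, describes where compound 1 sits, the expectation is that compound 4 stays close to that limit. The expected step is a number no higher from compound 1 to compound 4 (the limit leaves the size open), nothing beyond the usual scatter. Compound 4 is estimated at 25000 nM, with a range from 10000 nM to 60000 nM, and it is quite likely that this assay again reports only a limit.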

Compound 4, half-maximal inhibitory concentration: 16900 nM
Estimate against measurement, compound 4: 1.5-fold (0.17 log units) above, and the stated range covers the measured number.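

Compound 4 gives 16900 nM in this assay, so this core now has a real number with a ring amine on the thiocarbonyl carbon, something compound 1 did not provide. Putting piperidin-1-yl in place of methyl(phenyl)amino at that carbon amounts to an at least 1.4-fold lower number from compound 1 to compound 4 (0.17 log units; that floor lies within the scatter), which means the data show a change no further than the floor printed with it, while a larger change is not ruled out. The real size of this step stays open because compound 1 rests on a limit and not on a number: the limit of > 25000 nM in this assay, at which 2 of the 4 values shown sit.

What the compounds shown leave open is whether another amine on the same thiocarbonyl carbon of this core, such as dimethylamino or pyrrolidin-1-yl, would move the number any further than piperidin-1-yl does. Compound 2 and compound 3 differ from compound 4 in more than one place, so they cannot say whether the aromatic ring that leaves with methyl(phenyl)amino matters, and a pair with an N-methyl-N-benzylamino group in that place would be needed to start separating this.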